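Exchanging the Benzyl Aryl in a Weakly Active Series

The source may report more compounds than this note shows. Statements on the series, on what has been measured and on what is new or still open speak of the compounds shown alone.

Measured compounds:
compound 1 `O=C1/C(=C\c2ccccc2)c2c(ncn2COCc2ccccc2)CCN1Cc1ccc(F)cc1` — 24800 nM
compound 2 `Cc1ccccc1CN1CCc2ncn(COCc3ccccc3)c2/C(=C/c2ccccc2)C1=O` — 25300 nM

In a functional assay on A2780 cells (Homo sapiens) for inhibition, read by MTT assay, with a stated time of 72 h (a higher number here means a weaker inhibitor, a lower number a stronger inhibitor), compound 1 gives 24800 nM. In this assay compound 2 gives 25300 nM. Compound 1 holds the lowest of the two numbers, the nearest being compound 2, and that gap is within the scatter, so no order between them is claimed. Within the data shown here, the single measured step, a 1.0-fold higher number from compound 1 to compound 2 (0.01 log units; within the scatter), shows that exchanging one aryl group for another on the saturated chain carbon bound to the amide-type nitrogen in the ring left the number essentially unchanged.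

Compound 3 `O=C1/C(=C\c2ccccc2)c2c(ncn2COCc2ccccc2)CCN1Cc1ccc2ccccc2c1` carries the change (naphthalen-2-yl in place of 4-fluorophenyl on a saturated chain carbon bound to an amide-type nitrogen in a ring). The step from compound 1 to compound 2 is the only one that bears on it, being another aryl exchange at the same place, and it was within the scatter. Compound 3 is therefore expected to show no step beyond the scatter, a 1.1-fold lower number from compound 1 to compound 3 (0.05 log units; within the scatter). The estimate for compound 3 in this assay is 22000 nM, within 7000 nM to 60000 nM.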

Compound 3, half-maximal inhibitory concentration: 72800 nM
Compound 3: the middle estimate sits 3.3-fold (0.52 log units) below what was measured, outside the stated range (above it).
By their numbers in this assay, from the lowest: compounds 1 and 2 (each within the scatter of the next); then compound 3.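

The earlier pair suggested that this place, on a saturated chain carbon bound to an amide-type nitrogen in a ring, was indifferent to the aryl group, but in this assay naphthalen-2-yl does move the number (a 2.9-fold higher number from compound 1 to compound 3 (0.47 log units; beyond the scatter)) and (a 2.9-fold higher number from compound 2 to compound 3 (0.46 log units; beyond the scatter)). The exchange is therefore not always silent here: 4-fluorophenyl and 2-methylphenyl stay within the scatter of each other, while naphthalen-2-yl gives a modest step towards weaker inhibition. No evidence is available on what lies behind this step.

The three compounds leave open whether any group at this place can bring the number down, since all of them carry a carbon-only aromatic ring there. A pyridin-3-yl, a cyclohexyl or a phenyl bearing a carboxylic acid or an amine would test this.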